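Will a chloro group move compound 3?

This account rests on a few compounds, and the source may have more. Where it says the series, first, only, none or still open, it means among the compounds named here.

In a functional assay on MCF7 cells (Homo sapiens) for antiproliferative activity, read by MTT assay (on this read-out lower numbers stand for stronger inhibition and higher numbers for weaker inhibition), compound 3 (`C/C(=N/NC(=O)c1ccc(S(N)(=O)=O)cc1)c1ccccc1`) gives 20100 nM. Compound 1 (`NS(=O)(=O)c1ccc(C(=O)N/N=C(/CS(=O)(=O)c2ccccc2)c2ccccc2)cc1`) gives 10700 nM and compound 2 (`NS(=O)(=O)c1ccc(C(=O)N/N=C(/CS(=O)(=O)c2ccccc2)c2ccc(Br)cc2)cc1`) gives 19100 nM in this assay. These three numbers all lie within the usual scatter of one another, so compound 3 sits level with the other two.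

Compound 4 (`C/C(=N/NC(=O)c1ccc(S(N)(=O)=O)cc1)c1ccc(Cl)cc1`) is compound 3 with chloro in place of hydrogen on an aromatic carbon, para to a large group (chloro in place of hydrogen on an aromatic carbon). Among the measured compounds shown here, the closest precedent is a similar swap, bromo in place of hydrogen on an aromatic carbon, which gave a 1.8-fold higher number from compound 1 to compound 2 (0.25 log units; within the scatter). A second, quite different change, hydrogen in place of phenylsulfonyl, gave a 1.9-fold higher number from compound 1 to compound 3 (0.27 log units; within the scatter) and says little about a halogen. For the measured compounds named here, this is thin evidence, since no chloro compound has been measured yet.

No change beyond the scatter is therefore expected, and the estimated step is a 1.0-fold higher number from compound 3 to compound 4 (0.02 log units; within the scatter). For compound 4 the expected value is 21000 nM, with an estimated range from 9000 nM to 48000 nM.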

Compound 4, half-maximal inhibitory concentration: 3750 nM
Estimate against measurement, compound 4: 5.6-fold (0.75 log units) above, outside the stated range (below it).
By their numbers in this assay, from the lowest: compound 4; then compounds 1, 2 and 3 (each within the scatter of the next).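

Phenyl to 4-chlorophenyl is the first change here to move the number beyond the scatter: in this assay, it gave a 5.4-fold lower number from compound 3 to compound 4 (0.73 log units; beyond the scatter). The earlier halogen swap, with a 1.8-fold higher number from compound 1 to compound 2 (0.25 log units; within the scatter), stayed within the scatter, so a halogen on this ring does not give the same result in every case. Those two steps differ both in the halogen and in the chain carrying the ring, and nothing measured here explains the difference.

The compounds shown leave open whether the drop belongs to chloro itself or would also follow from bromo on compound 3, and whether chloro would do the same on compound 1. They also leave open what a different group on this carbon, such as fluoro, methoxy or an amine, would do.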